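Cyano addition on the pyrrolidinyl-bearing ring of compound 1

This account rests on a few compounds, and the source may have more. Where it says the series, first, only, none or still open, it means among the compounds named here.

Measured so far:
Compound 1 `CN1CCC(S(=O)(=O)c2ccc3nc(NC(=O)NC(=O)c4cc(N5CCCC5)ccc4Cl)sc3c2)CC1` gives 0.92 nM in an assay on HEK293 cells for displacement of a labelled ligand from growth hormone secretagogue receptor type 1 (Homo sapiens), with a stated time of 60 min; a higher number here means a weaker inhibitor, a lower number a stronger inhibitor.
Compound 2 `Cc1ccnn1-c1ccc(Cl)c(C(=O)NC(=O)Nc2nc3ccc(S(=O)(=O)C4CCN(C)CC4)cc3s2)c1` gives 33 nM in this assay.

Compound 1 stands lowest of the two numbers; the nearest is compound 2, reached by a 36-fold higher number from compound 1 to compound 2 (1.55 log units; beyond the scatter), which goes with 5-methyl-1H-pyrazol-1-yl in place of pyrrolidin-1-yl on an aromatic carbon. Compound 3 `CN1CCC(S(=O)(=O)c2ccc3nc(NC(=O)NC(=O)c4cc(N5CCCC5)c(C#N)cc4Cl)sc3c2)CC1` keeps the pyrrolidin-1-yl group and differs from compound 1 by cyano in place of hydrogen on an aromatic carbon. For the measured compounds named here, no measured step bears on this change: the single step on record concerns exchange of the pyrrolidin-1-yl group itself, not addition of a further group to that ring, so it gives no direction for compound 3. With the core and the pyrrolidin-1-yl group unchanged, the step is expected to stay near the scatter in either direction. Compound 3 is therefore estimated at 1.5 nM, with a range of 0.4 nM to 6 nM. The expected step is a 1.6-fold higher number from compound 1 to compound 3 (0.21 log units; within the scatter).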

Compound 3, half-maximal inhibitory concentration: 0.4 nM
Compound 3: middle estimate off by 3.8-fold (0.57 log units), on the high side, within the range that was stated.
By their numbers in this assay, from the lowest: compound 3; then compound 1; then compound 2.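

The ring bearing the pyrrolidin-1-yl group tolerates a further substituent: in this assay, cyano in place of hydrogen on the carbon ortho to the pyrrolidin-1-yl group, meta to the chloro group and para to a large group gives a 2.3-fold lower number from compound 1 to compound 3 (0.36 log units; beyond the scatter). For the compounds shown here, this modest step is the first on record that leaves the pyrrolidin-1-yl group in place, and it runs opposite in direction to the larger exchange of that group, a 36-fold higher number from compound 1 to compound 2 (1.55 log units; beyond the scatter). Nothing available accounts for the lower number with cyano at this position.

As far as these compounds go, it remains open whether fluoro, methoxy or a carboxylic acid on the same aromatic carbon would give a similar step. From the compounds shown here alone, it is also open whether cyano there would shift the number the same way with 5-methyl-1H-pyrazol-1-yl in place of pyrrolidin-1-yl.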